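A few compounds are considered here, and "the series" means these few. Any claim that something is new, unique, unknown or untested is made for them only; others in the source may bear on it.

The numbers come from a functional assay on the whole organism for inhibition, with Scenedesmus acutus as the target (a higher number here means a weaker inhibitor, a lower number a stronger inhibitor), in which three compounds have been measured. Compound 2 `S=c1n(-c2ccc(Cl)cc2)c(=S)n2n1CCCC2` gives 61.7 nM, the second highest of the three numbers. Compound 1 `CC(C)Oc1cc(-n2c(=S)n3n(c2=S)CCCC3)c(F)cc1Cl` gives 7.59 nM, a lower number than compound 2 by more than the usual scatter, while compound 3 `S=c1n(-c2ccccc2)c(=S)n2n1CCCC2` gives 7940 nM. Within the data shown here, the only single-point step among them runs a 130-fold higher number from compound 2 to compound 3 (2.11 log units; beyond the scatter), so taking away the chloro group costs a great deal.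

Compound 4 `Cc1cc(Cl)ccc1-n1c(=S)n2n(c1=S)CCCC2` differs from compound 2 in one place: methyl in place of hydrogen on an aromatic carbon. Among the measured compounds shown here, no measured step tests a methyl group on this ring; the step from compound 2 to compound 3 concerns only the chloro group, which compound 4 keeps. The gap between compound 1 and compound 2 shows that further groups on the ring can go with a lower number, but those groups are not a methyl. A step of a 1.2-fold lower number from compound 2 to compound 4 (0.09 log units; within the scatter) is therefore expected, within or close to the scatter. Compound 4 is estimated at 50 nM, with a range from 15 nM to 200 nM.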

Compound 4, half-maximal inhibitory concentration: 105 nM
Compound 4: middle estimate off by 2.1-fold (0.32 log units), on the low side, within the range that was stated.
By their numbers in this assay, from the lowest: compound 1; then compounds 2 and 4 (each within the scatter of the next); then compound 3.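

Placing a methyl on the aromatic carbon ortho to a large group and meta to a chloro group gives a step in this assay that stays inside the usual scatter (a 1.7-fold higher number from compound 2 to compound 4 (0.23 log units; within the scatter)), so compound 2 and compound 4 cannot be told apart here. This position on the ring can therefore carry a single methyl without a clear cost, which contrasts with the large step seen at the chloro group (a 130-fold higher number from compound 2 to compound 3 (2.11 log units; beyond the scatter)). Nothing measured on these compounds offers an explanation for this result.

Going by these compounds, whether a longer chain such as ethyl, or an amine or a methoxy group, would be accepted at this same carbon remains open. So does whether a methyl here would behave the same way on a ring without the chloro group.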